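Notes on the aryl change from compound 3 to compound 4

The compounds below may be only part of what the source reports. "The series", "measured", "known", "first", "only" and "open" are said of these compounds alone.

Compound 1 `C=CCn1c(=O)/c(=C\c2ccccc2Cl)[nH]c(=O)/c1=C\c1ccccc1OC` gives 4400 nM in a functional assay on MOLT-4 cells (Homo sapiens) for cytotoxicity, read by CCK-8 assay, with a stated time of 72 h; on this read-out lower numbers stand for stronger inhibition and higher numbers for weaker inhibition. Compound 2 `C=CCn1c(=O)/c(=C\c2ccc(Cl)c(Cl)c2)[nH]c(=O)/c1=C\c1ccccc1OC` is reported as "not active" (no number reported) in this assay, without a number. Going by the values given here, compound 3 `C=CCn1c(=O)/c(=C\c2cc(Br)ccc2F)[nH]c(=O)/c1=C\c1ccccc1OC` gives 12900 nM in this assay and so holds the higher of the two numbers recorded; its nearest neighbour is compound 1, and the only one-place step seen so far, a 2.9-fold higher number from compound 1 to compound 3 (0.47 log units; beyond the scatter), is a modest rise.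

Compound 4 `C=CCn1c(=O)/c(=C\c2ccc(C)cc2)[nH]c(=O)/c1=C\c1ccccc1OC` differs from compound 3 by 4-methylphenyl in place of 5-bromo-2-fluorophenyl on a double-bonded chain carbon bound to an aromatic carbon. Among the compounds with values here, the one measured step that bears on this change sits at the same position: a 2.9-fold higher number from compound 1 to compound 3 (0.47 log units; beyond the scatter). That change of aryl group at this site cost only a modest amount, whereas compound 2 at "not active" (no number reported) shows that another aryl group at the same site can remove measurable activity altogether. For compound 4 a step of about the size already seen at this site, with no secure direction, is expected, a 1.4-fold lower number from compound 3 to compound 4 (0.16 log units; within the scatter). Compound 4 is accordingly estimated at 9000 nM in this assay, within 3000 nM to 30000 nM.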

Compound 4, half-maximal inhibitory concentration: "not active" (no number reported)
The entry for compound 4 holds no number; no gap can be computed for the estimate.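

Going by these compounds alone, compound 4 stands at "not active" (no number reported), so no step from compound 3 to compound 4 can be read. The compounds shown leave open what separates compound 1 and compound 3, which carry numbers, from compound 2 and compound 4, which carry none. No measurement offers an explanation for this result.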